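The source may hold more compounds than are shown below. What is called first, only, known or untested is meant among the compounds shown, and "the series" means these compounds.

Measured compounds:
Compound 1, `Nc1ccc(-c2cc(=O)c3c(N)c(F)cc(F)c3o2)cc1F`. In a functional assay on HeLa cells (Homo sapiens) for cytotoxicity, read by neutral red uptake, with a stated time of 3 days (a lower number here means a stronger inhibitor, a higher number a weaker inhibitor), compound 1 gives > 100000 nM, a limit of the assay and not a number.
Compound 2, `CCCCCCc1c(F)c(N)c2c(=O)cc(-c3ccc(N)c(F)c3)oc2c1F`. In this assay compound 2 gives 21000 nM.
Compound 3, `CCOC(=O)c1c(F)c(N)c2c(=O)cc(-c3ccc(N)c(F)c3)oc2c1F`. In this assay compound 3 gives > 100000 nM, again a limit of the assay.

Compound 3 thus stands at the limit of > 100000 nM in this assay, at which 2 of the 3 values shown sit, and no number is known for it. Compound 4, `CCCOCc1c(F)c(N)c2c(=O)cc(-c3ccc(N)c(F)c3)oc2c1F`, differs from compound 3 by propoxymethyl in place of ethoxycarbonyl on an aromatic carbon. Going by the values given here, the steps that bear on this are an at least 4.7-fold higher number from compound 2 to compound 3 (0.67 log units; beyond the scatter) and an at least 4.7-fold lower number from compound 1 to compound 2 (0.67 log units; beyond the scatter), while a step that the two limits leave unreadable from compound 1 to compound 3. Hexyl is the only group on this carbon that has given a readable number. For a chain in place of ethoxycarbonyl, a number below the limit is expected, though a further limit remains possible. Compound 4 is expected at 60000 nM, within a range from 20000 nM to 150000 nM. The expected step is an at least 1.6-fold lower number from compound 3 to compound 4 (0.22 log units; that floor lies within the scatter).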

Compound 4, half-maximal inhibitory concentration: 78000 nM
Beside the measured number, compound 4's estimate is 1.3-fold (0.11 log units) below it; the measured number falls inside the stated range.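

Propoxymethyl on this aromatic carbon gives a readable number in this assay, so a readable number at this position no longer rests on hexyl alone. Set against the two limits of the assay, the result gives only floors: an at least 1.2-fold lower number from compound 3 to compound 4 (0.10 log units; that floor lies within the scatter) and an at least 1.2-fold lower number from compound 1 to compound 4 (0.10 log units; that floor lies within the scatter). Among the chains, propoxy in place of pentyl gives a 3.7-fold higher number from compound 2 to compound 4 (0.57 log units; beyond the scatter), so two chain groups at this carbon already differ beyond the scatter.

As far as these compounds go, whether an amine, a carboxylic acid or a chain longer than hexyl at this carbon would give a number or another limit stays open. From the compounds shown here alone, the true sizes of the two floored steps also remain unknown.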